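Bromo for chloro, carried over to a second core

This account rests on a few compounds, and the source may have more. Where it says the series, first, only, none or still open, it means among the compounds named here.

Compound 1 `Cn1c(=O)c2[nH]c(SCC(=O)c3ccc(Cl)cc3)nc2n(C)c1=O` and compound 2 `Cn1c(=O)c2[nH]c(SCC(=O)c3ccc(Br)cc3)nc2n(C)c1=O` share one core. In a functional assay on MCF7 cells (Homo sapiens) for inhibition, read by MTT assay, with a stated time of 48 h (on this read-out lower numbers stand for stronger inhibition and higher numbers for weaker inhibition), compound 1 gives 8400 nM and compound 2 gives 7600 nM. The change from compound 1 to compound 2 is bromo in place of chloro on an aromatic carbon, and it made a step of a 1.1-fold lower number from compound 1 to compound 2 (0.04 log units; within the scatter). Compound 3 `Cn1c(=O)[nH]c2nc(SC/C(=N/O)c3ccc(Cl)cc3)[nH]c2c1=O` is built on another core; the difference between the two cores is not broken down here. In this assay compound 3 gives 1400 nM, the lowest of the three numbers, and its gaps to compound 1 and to compound 2 both lie beyond the scatter.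

Compound 4 `Cn1c(=O)[nH]c2nc(SC/C(=N/O)c3ccc(Br)cc3)[nH]c2c1=O` has not been measured. It differs from compound 3 by bromo in place of chloro on an aromatic carbon, the same change as that between compound 1 and compound 2, at the same place. In this assay compound 4 is expected to show a step of a 1.1-fold lower number from compound 3 to compound 4 (0.03 log units; within the scatter). This expectation rests on the step of a 1.1-fold lower number from compound 1 to compound 2 (0.04 log units; within the scatter), which lay within the scatter, and on compound 3 at 1400 nM. The estimate for compound 4 in this assay is 1300 nM, with a range from 600 nM to 2800 nM.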

Compound 4, half-maximal inhibitory concentration: 1700 nM
For compound 4 the middle estimate is 1.3-fold (0.12 log units) below the measured one, within the range that was stated.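

In this assay, bromo in place of chloro on an aromatic carbon gives a 1.2-fold higher number from compound 3 to compound 4 (0.08 log units; within the scatter), so on the core of compound 3 this change again stays within the scatter. Set beside the earlier step, the change carries from one core to the other with no difference that can be told apart: the same change on two cores in this assay, a 1.1-fold lower number (0.04 log units; within the scatter) from compound 1 to compound 2 and a 1.2-fold higher number (0.08 log units; within the scatter) from compound 3 to compound 4, 1.3-fold (0.13 log units) apart, within the scatter of two such steps. This covers one exchange of halogens, at one place, in one cell read-out; it does not show that a different substituent would carry over in the same way, and it says nothing about what the two cores themselves contribute.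

Still open, from the compounds shown here alone, is how other groups in place of the halogen on the aromatic ring would read, such as a methoxy, a nitrile or an amine. Also open is what the oxime contributes apart from the core, as the compounds shown never change the ketone to the oxime on a single core.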